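Swapping Ethoxy for Pyrrolidin-1-yl on Compound 1

The compounds below may be only part of what the source reports. "The series", "measured", "known", "first", "only" and "open" are said of these compounds alone.

In a functional assay on HepG2 cells (Homo sapiens) for cytotoxicity, read by MTT assay, with a stated time of 48 h (on this read-out lower numbers stand for stronger inhibition and higher numbers for weaker inhibition), compound 1 (`CCOC(=O)/C=C/c1ccc2c(c1)C(=O)C(=O)N2Cc1ccc(OC)cc1`) gives 90 nM as the lowest of three numbers. Compound 3 (`COC(=O)/C=C/c1ccc2c(c1)C(O)C(=O)N2Cc1ccc(OC)cc1`) gives 380 nM and compound 2 (`COC(=O)/C=C/c1ccc2c(c1)C(=O)C(=O)N2C`) gives 530 nM on the same read-out, both beyond the usual scatter from compound 1. Compound 4 (`COc1ccc(CN2C(=O)C(=O)c3cc(/C=C/C(=O)N4CCCC4)ccc32)cc1`) has not been measured. Going by the values given here, it carries pyrrolidin-1-yl in place of ethoxy on a carbonyl carbon and no measured pair shows this change alone, so any expectation is loose. Compound 1 already stands lowest at 90 nM among the three, so a rise is the likelier direction in this assay for the new structure. The expected step is a moderate rise, estimated as a 3.3-fold higher number from compound 1 to compound 4 (0.52 log units; beyond the scatter) on this read-out. For compound 4 the estimated value is 300 nM with an expected range from 80 nM to 1200 nM on the same read-out.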

Compound 4, half-maximal inhibitory concentration: 7810 nM
The estimate for compound 4 lay 26-fold (1.42 log units) below the measured number; measured number outside the range, above it.
By their numbers in this assay, from the lowest: compound 1; then compounds 3 and 2 (each within the scatter of the next); then compound 4.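

In this assay pyrrolidin-1-yl in place of ethoxy on a carbonyl carbon gives an 87-fold higher number from compound 1 to compound 4 (1.94 log units; beyond the scatter) and so shows that this position is far from indifferent to the group it carries. The earlier compounds shown here offered no single-place pair, so they could not show this. Nothing available accounts for the size of the step.

From the compounds shown here alone, whether the change in number follows from the ring or from nitrogen replacing oxygen on the carbonyl carbon remains open. A diethylamino group or a hydroxyl giving the carboxylic acid at that carbon would help separate these readings.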